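The compounds below may be only part of what the source reports. "The series", "measured", "known", "first", "only" and "open" are said of these compounds alone.

Three compounds share one core and differ only in the group carried on the saturated chain carbon bound to an oxygen on an aromatic ring. In an assay on CHO cells for displacement of a labelled ligand from melanin-concentrating hormone receptor 1 (Rattus norvegicus), read by scintillation counting, with a stated time of 1 h (on this read-out higher numbers stand for weaker inhibition and lower numbers for stronger inhibition), compound 1 `Cc1c(C2CC2)nc2ccc(-n3ccc(OCc4ccc(Br)cc4)cc3=O)cn12` gives 9.3 nM, compound 2 `Cc1c(C2CC2)nc2ccc(-n3ccc(OCc4ccc(C(F)(F)F)cc4)cc3=O)cn12` gives 82 nM, and compound 3 `Cc1c(C2CC2)nc2ccc(-n3ccc(OCc4ccccn4)cc3=O)cn12` gives 150 nM, a number far from that of compound 1 but close to that of compound 2. The steps of a 16-fold higher number from compound 1 to compound 3 (1.21 log units; beyond the scatter) and a 1.8-fold higher number from compound 2 to compound 3 (0.26 log units; within the scatter) show that putting pyridin-2-yl in place of 4-bromophenyl or 4-(trifluoromethyl)phenyl gave higher numbers. Compound 4 `Cc1c(C2CC2)nc2ccc(-n3ccc(OCc4cncnc4)cc3=O)cn12` carries the change (pyrimidin-5-yl in place of pyridin-2-yl on a saturated chain carbon bound to an oxygen on an aromatic ring). Within the data shown here, no measured step swaps one such ring for another, so only a small step is expected, a 1.7-fold higher number from compound 3 to compound 4 (0.22 log units; within the scatter), towards a slightly higher number. Compound 4 is therefore estimated at 250 nM, between 80 nM and 800 nM.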

Compound 4, half-maximal inhibitory concentration: > 1000 nM
Compound 4 ended at the assay's limit (the forecaster's own chance of this, stated with the estimate: 5%); middle value at least 4.0-fold (0.60 log units) away from the limit.
By their numbers in this assay, from the lowest: compound 1; then compounds 2 and 3 (each within the scatter of the next). At a limit, above all of these: compound 4.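

Compound 4 gives a limit of the assay, not a number: the limit of > 1000 nM in this assay, at which 1 of the 4 values shown sits. On this saturated chain carbon, one nitrogen-containing ring therefore cannot simply replace another: the same count of heavy atoms with pyrimidin-5-yl in place of pyridin-2-yl gives an at least 6.6-fold higher number from compound 3 to compound 4 (0.82 log units; beyond the scatter), whereas the earlier step between compounds 2 and 3 stayed within the scatter. Against the two substituted phenyl groups, the gaps reach an at least 12-fold higher number from compound 2 to compound 4 (1.08 log units; beyond the scatter) and an at least 100-fold higher number from compound 1 to compound 4 (2.03 log units; beyond the scatter).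

The compounds shown leave open how plain phenyl or pyridin-3-yl would read here. They therefore cannot separate the effect of the second ring nitrogen from that of the point where the ring is joined.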